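Moving from isopropyl to an amide-bearing chain

A few compounds are considered here, and "the series" means these few. Any claim that something is new, unique, unknown or untested is made for them only; others in the source may bear on it.

Compound 3 `CC(C)Oc1cc(=O)oc2cc(OCc3cccc(Cl)c3)ccc12` is the weakest of the three measured compounds in an assay on isolated protein (strain Sprague-Dawley) for inhibition of Amine oxidase [flavin-containing] B (Rattus norvegicus), read by spectrophotometry, with a stated time of 5 min (a higher number here means a weaker inhibitor, a lower number a stronger inhibitor), where compound 3 gives 24500 nM. Compound 1 `O=c1cc(O)c2ccc(OCc3cccc(Br)c3)cc2o1` gives 490 nM in this assay, and compound 2 `CCOc1cc(=O)oc2cc(OCc3cccc(F)c3)ccc12` gives 263 nM; both numbers lie well below that of compound 3, beyond the scatter. The next compound, compound 4 `CN(C)C(=O)COc1cc(=O)oc2cc(OCc3cccc(Cl)c3)ccc12`, differs from compound 3 in one place: (dimethylcarbamoyl)methyl in place of isopropyl on an oxygen on an aromatic ring. Among the measured compounds shown here, no measured pair shows this same change, so its effect can only be guessed. The step from compound 3 to compound 4 is expected to be small, a slight move toward stronger inhibition or none beyond the scatter, a 2.0-fold lower number from compound 3 to compound 4 (0.31 log units; beyond the scatter). Compound 4 is therefore estimated at 12000 nM, with a range from 2000 nM to 70000 nM.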

Compound 4, half-maximal inhibitory concentration: 501 nM
Compound 4: middle estimate off by 24-fold (1.38 log units), on the high side, and the stated range ends above it.
By their numbers in this assay, from the lowest: compounds 2, 1 and 4 (each within the scatter of the next); then compound 3.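

On an oxygen on an aromatic ring, (dimethylcarbamoyl)methyl in place of isopropyl strengthens inhibition in this assay by a large step (a 49-fold lower number from compound 3 to compound 4 (1.69 log units; beyond the scatter)). This first one-place comparison shows that inhibition responds strongly to the group on this oxygen, at least with the chlorine-bearing benzyl ether of compounds 3 and 4. No measurement given here explains the step. From the compounds shown here alone, it remains open whether the amide or the longer chain matters more. A carboxylic acid, a methyl ester, a secondary amide or a longer alkyl chain at this oxygen could separate the two.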